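The source may report more compounds than this note shows. Statements on the series, on what has been measured and on what is new or still open speak of the compounds shown alone.

Compound 1 `Cc1ccoc1C(=O)N1CCCn2nc(C(=O)Nc3ccc(F)cc3F)cc2C1`: 5000 nM
Compound 2 `Cc1ccccc1NC(=O)c1cc2n(n1)CCCN(C(=O)c1occc1C)C2`: 1100 nM
Compound 3 `COc1cccc(NC(=O)c2cc3n(n2)CCCN(C(=O)c2occc2C)C3)c1`: 30000 nM

These values come from an ADME assay on BEAS-2B cells (Homo sapiens) for cytotoxicity, read by fluorescence, with a stated time of 48 h; a higher number here means that more compound is tolerated, a lower number that less compound is tolerated. Compound 3 has the highest number of the three at 30000 nM, and its gaps to both other compounds lie beyond the scatter.

Compound 4 `Cc1ccoc1C(=O)N1CCCn2nc(C(=O)Nc3ccc(F)cc3Cl)cc2C1` keeps the shared core of compound 3 but carries 2-chloro-4-fluorophenyl in place of 3-methoxyphenyl on an amide-type nitrogen.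

The same position has already been varied, so three measured steps bear on this change. The move to the 3-methoxyphenyl group gave a 6.0-fold higher number from compound 1 to compound 3 (0.78 log units; beyond the scatter), a modest rise, and a 27-fold higher number from compound 2 to compound 3 (1.44 log units; beyond the scatter), a large one. Between the other two groups, the data show a 4.5-fold lower number from compound 1 to compound 2 (0.66 log units; beyond the scatter). Thus, in this small set, both compounds without the 3-methoxyphenyl group have lower numbers than compound 3, and no compound goes against that. Among the compounds with values here, no measurement yet covers the 2-chloro-4-fluorophenyl group itself, but its name comes closest to the 2,4-difluorophenyl group of compound 1.

A clear fall beyond the scatter is therefore expected, and the estimated step is a 10-fold lower number from compound 3 to compound 4 (1.00 log units; beyond the scatter). For compound 4 the expected value is 3000 nM, with an estimated range of 1000 nM to 9000 nM.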

Compound 4, half-maximal cytotoxic concentration: 30000 nM
Compound 4: the middle estimate sits 10-fold (1.00 log units) below what was measured; the whole stated range lies below it.
By their numbers in this assay, from the lowest: compound 2; then compound 1; then compounds 3 and 4 (each within the scatter of the next).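

In this assay the change shows no change at the digits printed from compound 3 to compound 4 (within the scatter) and so breaks the earlier pattern, in which both compounds without the 3-methoxyphenyl group had lower numbers than compound 3: a high number here does not depend on that group. Within the data shown here, the new compound also gives the first single-atom comparison at this aromatic ring, with chloro in place of fluoro on an aromatic carbon producing a 6.0-fold higher number from compound 1 to compound 4 (0.78 log units; beyond the scatter) and showing that one halogen swap can matter as much as replacing the whole ring substituent pattern, while the step from the 2-methylphenyl compound is a 27-fold higher number from compound 2 to compound 4 (1.44 log units; beyond the scatter) and leaves compound 2 the lowest of the four. No measured evidence is available to explain why these closely related groups give such different numbers.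

On these data alone, what remains open is whether the gain follows chloro itself or only chloro together with the 4-fluoro group, which a 2-chlorophenyl or 2-bromo-4-fluorophenyl group on the same amide-type nitrogen could test. As far as these compounds go, it is also open how far this tolerance extends to quite different groups at this place, such as a phenyl ring carrying a carboxylic acid or an amine.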